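The compounds below may be only part of what the source reports. "The series", "measured", "known", "first", "only" and "open" are said of these compounds alone.

The measured compounds, each with its number:

In an assay on cells for binding affinity to Myc proto-oncogene protein (Homo sapiens) (on this read-out higher numbers stand for weaker inhibition and lower numbers for stronger inhibition), compound 1 `N#Cc1ccc(-c2cc(-c3ccc(C(N)=O)cc3)cc(-c3ccco3)n2)cc1` gives 3000 nM. In this assay compound 2 `N#Cc1ccc(-c2cc(-c3ccc(C(N)=O)cc3)cc(-c3cnco3)n2)cc1` gives > 100000 nM, which is a limit of the assay rather than a number. In this assay compound 3 `Cn1ccnc1-c1cc(-c2ccc(C(N)=O)cc2)cc(-c2ccc(C#N)cc2)n1` gives 40000 nM.

Among the two plain numbers, compound 3 stands highest; its nearest neighbour is compound 1, and the gap is a 13-fold higher number from compound 1 to compound 3 (1.12 log units; beyond the scatter). The third value is the limit of compound 2 (the limit of > 100000 nM in this assay, at which 1 of the 3 values shown sits).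

Compound 4 `Cn1nncc1-c1cc(-c2ccc(C(N)=O)cc2)cc(-c2ccc(C#N)cc2)n1` differs from compound 3 in one place: 1-methyl-1H-1,2,3-triazol-5-yl in place of 1-methyl-1H-imidazol-2-yl on an aromatic carbon. Within the data shown here, two measured steps bear on swapping one five-membered ring for another at this position. Exchanging the furan for an azole gave an at least 33-fold higher number from compound 1 to compound 2 (1.52 log units; beyond the scatter) and a 13-fold higher number from compound 1 to compound 3 (1.12 log units; beyond the scatter), both large; between the two azoles the change was an at least 2.5-fold lower number from compound 2 to compound 3 (0.39 log units; beyond the scatter), pointing the other way and smaller. Each added ring nitrogen or oxygen in place of the furan has so far raised the number, so a triazole is expected to raise it again.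

For compound 4 in this assay the expected step is a 2.0-fold higher number from compound 3 to compound 4 (0.30 log units; within the scatter), an estimate of 80000 nM with a range from 20000 nM to 300000 nM, and a real chance that only a limit is reported.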

Compound 4, half-maximal inhibitory concentration in the Myc proto-oncogene protein assay: 40000 nM
Beside the measured number, compound 4's estimate is 2.0-fold (0.30 log units) above it; measured number inside the range.
By their numbers in the Myc proto-oncogene protein assay, from the lowest: compound 1; then compounds 3 and 4 (each within the scatter of the next). At a limit, above all of these: compound 2.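

In the Myc proto-oncogene protein assay, the 1-methyl-1H-1,2,3-triazol-5-yl group and the 1-methyl-1H-imidazol-2-yl group read alike at this position, with no change at the digits printed from compound 3 to compound 4 (within the scatter), so the third ring hetero atom does not extend the rise seen on leaving the furan, and the gap to the furan compound is the same for both azoles, with a 13-fold higher number from compound 1 to compound 4 (1.12 log units; beyond the scatter). Among these compounds, the value of compound 2 is a limit of the assay, and the only step it allows here is an at least 2.5-fold lower number from compound 2 to compound 4 (0.39 log units; beyond the scatter). In a physicochemical assay for solubility, at pH 6 (a lower number here means a less soluble compound, a higher number a more soluble compound), compound 3 gives 8000 nM and compound 4 gives 32000 nM. The swap that leaves the binding number level does separate the two compounds in the physicochemical assay: the measured solubility of compound 3, 8000 nM, and of compound 4, 32000 nM, a 4.0-fold higher number (0.60 log units; beyond the scatter).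

Among the rings shown at this position, only the furan of compound 1 gives a number clearly lower than those of the azoles, so it remains open whether a thiophen-2-yl or a plain phenyl group would keep that lower number. On these data alone, it is also open whether a group of another kind on this carbon, such as a morpholine or a primary amine, would keep the binding number of compound 4 together with its solubility.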